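From 4-fluorophenyl to 2-chlorophenyl: notes on the series

The compounds below may be only part of what the source reports. "The series", "measured", "known", "first", "only" and "open" are said of these compounds alone.

Measured so far in a functional assay; on this read-out higher numbers stand for weaker inhibition and lower numbers for stronger inhibition
- compound 1 `CC(C)=CCOc1ccc2c(c1)OC(c1ccccc1Cl)CC2=O` gives 8020 nM
- compound 2 `CC(C)=CCOc1cc(O)c2c(c1)OC(c1ccc(F)cc1)CC2=O` gives 6060 nM

Compound 2 (6060 nM) lies within the scatter of compound 1, so these two numbers give no ranking. Compound 3 `CC(C)=CCOc1cc(O)c2c(c1)OC(c1ccccc1Cl)CC2=O` comes from compound 2 by a single change (2-chlorophenyl in place of 4-fluorophenyl on a saturated ring carbon), with 2-chlorophenyl in place of 4-fluorophenyl on a saturated ring carbon. Among the measured compounds shown here, no step between measured compounds isolates this swap. For the measured compounds named here, the only guide is compound 1 (8020 nM), which also carries 2-chlorophenyl and stands within the scatter of compound 2. In this assay no step beyond the scatter is therefore expected, and the estimated step is small (a 1.1-fold lower number from compound 2 to compound 3 (0.04 log units; within the scatter)). The estimate for compound 3 is 5500 nM with an expected range from 2200 nM to 14000 nM for the coming measurement.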

Compound 3, half-maximal inhibitory concentration: 4270 nM
The estimate for compound 3 lay 1.3-fold (0.11 log units) above the measured number; the measured number falls inside the stated range.
By their numbers in this assay, from the lowest: compounds 3, 2 and 1 (each within the scatter of the next).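

In this assay the swap to 2-chlorophenyl from 4-fluorophenyl on the saturated ring carbon next to the ring oxygen now has a step of its own (a 1.4-fold lower number from compound 2 to compound 3 (0.15 log units; within the scatter)), and this step stays within the scatter, so the two aryl groups cannot be told apart at this position. Hydroxy in place of hydrogen on an aromatic carbon also has its own step on the 2-chlorophenyl compounds (a 1.9-fold lower number from compound 1 to compound 3 (0.27 log units; within the scatter)), again within the scatter, so neither single change gives a ranking. No independent measurement bears on the reason for these small steps.

On these data alone, whether an amine or a carboxylic acid in place of the aryl group on that saturated ring carbon would give a step beyond the scatter stays open. So does the outcome of methoxy in place of the hydroxy.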